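A few compounds are considered here, and "the series" means these few. Any claim that something is new, unique, unknown or untested is made for them only; others in the source may bear on it.

Values measured so far in a functional assay on HepG2 cells (Homo sapiens) for cytotoxicity, read by MTT assay, with a stated time of 24 h (a higher number here means a weaker inhibitor, a lower number a stronger inhibitor), are these

- Compound 1 `CC(=O)Nc1ccc(S(=O)(=O)N2C/C(=C\c3ccc(C#N)cc3)C(=O)/C(=C/c3ccc(C#N)cc3)C2)cc1` gives 4880 nM
- Compound 2 `COc1cc(/C=C2\CN(S(=O)(=O)c3ccc(NC(C)=O)cc3)C/C(=C\c3cc(OC)c(OC)c(OC)c3)C2=O)cc(OC)c1OC` gives 3890 nM
- Compound 3 `CC(=O)Nc1ccc(S(=O)(=O)N2C/C(=C\c3ccc(C#N)cc3)C(=O)/C(=C/c3ccccc3F)C2)cc1` gives 4960 nM

Compound 3 (4960 nM) cannot be told apart from compound 1 or compound 2, since all three values lie within the usual scatter of one another. Compound 4 `COc1cc(/C=C2\CN(S(=O)(=O)c3ccc(NC(C)=O)cc3)C/C(=C\c3ccc(C#N)cc3)C2=O)cc(OC)c1OC` differs from compound 3 in one place (3,4,5-trimethoxyphenyl in place of 2-fluorophenyl on a double-bonded chain carbon bound to a double-bonded ring carbon). This exact swap has not been measured on its own, but two comparisons bear on it. Among the measured compounds shown here, the first is the only measured single-place step (a 1.0-fold higher number from compound 1 to compound 3 (0.01 log units; within the scatter)), which stayed within the scatter. The second compares compound 1 (4880 nM), which carries 4-cyanophenyl twice, with compound 2 (3890 nM), which carries 3,4,5-trimethoxyphenyl twice. These two values also lie within the scatter of each other, and compound 4 carries one of each group. No change beyond the scatter is therefore expected in this assay. The expected step is small (a 1.1-fold lower number from compound 3 to compound 4 (0.05 log units; within the scatter)). Compound 4 is estimated at 4400 nM with an expected range (2500 nM to 7500 nM).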

Compound 4, half-maximal inhibitory concentration: 2890 nM
For compound 4 the middle estimate is 1.5-fold (0.18 log units) above the measured one, and the stated range covers the measured number.
By their numbers in this assay, from the lowest: compounds 4, 2, 1 and 3 (each within the scatter of the next).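

In this assay, with 4-cyanophenyl held constant on one side of the shared core, the position on a double-bonded chain carbon bound to a double-bonded ring carbon has now carried three different groups. Placing 3,4,5-trimethoxyphenyl there gives a 1.7-fold lower number from compound 3 to compound 4 (0.23 log units; within the scatter) against 2-fluorophenyl and a 1.7-fold lower number from compound 1 to compound 4 (0.23 log units; within the scatter) against 4-cyanophenyl, so even this exchange of a 7-atom group for a 12-atom group with 3 hydrogen-bond acceptors stays within the usual variation between repeat measurements, and the same holds for the single swap that links the doubly trimethoxylated compound to the mixed one, a 1.3-fold lower number from compound 2 to compound 4 (0.13 log units; within the scatter). Nothing available here explains why these exchanges leave the value so little altered.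

Among the compounds shown here, every group seen at this position so far is a substituted phenyl ring, so it remains open whether a phenyl ring carrying an amine or a carboxylic acid, or a simple methyl group in place of the ring, would give a value beyond that variation. The compounds shown also leave open whether any change at this position can shift the cytotoxicity of this series at all.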